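A few compounds are considered here, and "the series" means these few. Any claim that something is new, unique, unknown or untested is made for them only; others in the source may bear on it.

Compounds measured so far:
- compound 1, `CC1(C)[C@@H]2CC[C@@]1(CS(=O)(=O)N1CCN(c3ncccc3C(F)(F)F)CC1)C(=O)C2`, a functional assay on CHO-K1 cells for antagonist activity at C-X-C chemokine receptor type 3 (Homo sapiens), read by FLIPR and calcium flux; a lower number here means a stronger inhibitor, a higher number a weaker inhibitor: > 31600 nM
- compound 2, `CC1(C)[C@@H]2CC[C@@]1(CS(=O)(=O)N1CCN(c3ncc(Br)cn3)CC1)C(=O)C2`, this assay: 631 nM

The value of compound 1 in this assay is a limit of the assay, not a number. Going by the values given here, compound 2 therefore holds the only actual number in this assay; the other entry is a limit, (the limit of > 31600 nM in this assay, at which 1 of the 2 values shown sits). Among the compounds with values here, the single measured step, an at least 50-fold lower number from compound 1 to compound 2 (1.69 log units; beyond the scatter), is large.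

Compound 3, `CC1(C)[C@@H]2CC[C@@]1(CS(=O)(=O)N1CCN(c3ccc(C(F)(F)F)nn3)CC1)C(=O)C2`, differs from compound 2 by 6-(trifluoromethyl)pyridazin-3-yl in place of 5-bromopyrimidin-2-yl on an amine nitrogen in a ring. Within the data shown here, the only step that bears on it is an at least 50-fold lower number from compound 1 to compound 2 (1.69 log units; beyond the scatter), where a trifluoromethyl-bearing six-membered azine in place of the bromopyrimidinyl went with a much higher number; compound 3 brings a trifluoromethyl group back, on a pyridazinyl rather than a pyridinyl. On that basis a move towards a higher number is expected in this assay. Among the measured compounds shown here, no measured compound carries a pyridazinyl ring, and the expected move is set smaller than the measured step. Compound 3 is expected at 3000 nM, within 600 nM to 20000 nM. The expected step is a 4.8-fold higher number from compound 2 to compound 3 (0.68 log units; beyond the scatter).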

Compound 3, half-maximal inhibitory concentration: 5010 nM
Compound 3: middle estimate off by 1.7-fold (0.22 log units), on the low side; low and high end bracket the measured number.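

On the amine nitrogen in a ring, a trifluoromethyl group on the azine does not by itself rule out a measurable number in this assay: 6-(trifluoromethyl)pyridazin-3-yl in place of 3-(trifluoromethyl)pyridin-2-yl gives an at least 6.3-fold lower number from compound 1 to compound 3 (0.79 log units; beyond the scatter). Going by these compounds alone, the entry for compound 1 is a limit, not a number: the limit of > 31600 nM in this assay, at which 1 of the 3 values shown sits. Against 5-bromopyrimidin-2-yl, the same group gives a 7.9-fold higher number from compound 2 to compound 3 (0.90 log units; beyond the scatter), so compound 2 keeps the lowest number so far.

Ring and substituent change together in every step, which leaves open whether the bromine, the placement of the ring nitrogens or both go with the lower number of compound 2. Also open, going by these compounds, is how a nitrile, a methoxy group or an amine on the azine would read in this assay.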